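Trifluoromethoxy for trifluoromethyl on the methylated benzimidazole core

The compounds below may be only part of what the source reports. "The series", "measured", "known", "first", "only" and "open" are said of these compounds alone.

Compound 1 `FC(F)(F)c1ccc(-c2ccc(-c3ccc(-c4nc5ccccc5[nH]4)cc3)cc2)cc1` gives 39100 nM in a functional assay on Gurav cells (Homo sapiens) for inhibition, read by sulforhodamine B assay (a lower number here means a stronger inhibitor of growth, a higher number a weaker inhibitor of growth), and compound 2 `FC(F)(F)Oc1ccc(-c2ccc(-c3ccc(-c4nc5ccccc5[nH]4)cc3)cc2)cc1` gives 100000 nM. The change between them, (trifluoromethoxy in place of trifluoromethyl on an aromatic carbon), made a 2.6-fold higher number from compound 1 to compound 2 (0.41 log units; beyond the scatter). Compound 3 `Cc1ccc2[nH]c(-c3ccc(-c4ccc(-c5ccc(C(F)(F)F)cc5)cc4)cc3)nc2c1` differs from compound 1 by methyl in place of hydrogen on an aromatic carbon. In this assay compound 3 gives 12000 nM, a step of a 3.3-fold lower number from compound 1 to compound 3 (0.51 log units; beyond the scatter). Compound 4 `Cc1ccc2[nH]c(-c3ccc(-c4ccc(-c5ccc(OC(F)(F)F)cc5)cc4)cc3)nc2c1`, not yet measured, carries the same change relative to compound 3, (trifluoromethoxy in place of trifluoromethyl on an aromatic carbon), and the words describing its place match those of the change from compound 1 to compound 2, so it is the same change on a different core. Given that it made a 2.6-fold higher number from compound 1 to compound 2 (0.41 log units; beyond the scatter), compound 4 is expected to show a step of a 2.6-fold higher number from compound 3 to compound 4 (0.41 log units; beyond the scatter) in this assay. The estimated value of compound 4 in this assay is 31000 nM, expected to lie between 12000 nM and 80000 nM.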

Compound 4, concentration for 50% growth inhibition: 11000 nM
Beside the measured number, compound 4's estimate is 2.8-fold (0.45 log units) above it; measured number outside the range, below it.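

The swap of trifluoromethyl for trifluoromethoxy does not carry over unchanged to the methylated core in this assay, where the step is a 1.1-fold lower number from compound 3 to compound 4 (0.04 log units; within the scatter), and it differs from the earlier step: the same change on two cores in this assay, a 2.6-fold higher number (0.41 log units; beyond the scatter) from compound 1 to compound 2 and a 1.1-fold lower number (0.04 log units; within the scatter) from compound 3 to compound 4, 2.8-fold (0.45 log units) apart, beyond the scatter of two such steps. Seen from the other side, the methyl change gives a 9.1-fold lower number from compound 2 to compound 4 (0.96 log units; beyond the scatter), and this also differs from its earlier counterpart: the same change on two cores in this assay, a 3.3-fold lower number (0.51 log units; beyond the scatter) from compound 1 to compound 3 and a 9.1-fold lower number (0.96 log units; beyond the scatter) from compound 2 to compound 4, 2.8-fold (0.45 log units) apart, beyond the scatter of two such steps. The two changes are therefore not additive across these compounds, but a single pair on each core shows neither why this is so nor how general it is.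

From the compounds shown here alone, it remains open how an amine or a carboxylic acid in place of trifluoromethoxy would behave on either core. Going by these compounds, it is also open whether a longer chain in place of the methyl would give the same pattern.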